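Notes on the core methyl: compound 1 to compound 4

This account rests on a few compounds, and the source may have more. Where it says the series, first, only, none or still open, it means among the compounds named here.

compound 1, `Cc1cnc(Nc2ccc(S(C)(=O)=O)cc2)nc1Nc1nc2ccccc2s1`: 460 nM in a functional assay on HeLa cells (Homo sapiens) for antiproliferative activity, read by MTT assay, with a stated time of 48 h; on this read-out lower numbers stand for stronger inhibition and higher numbers for weaker inhibition
compound 2, `Cc1cnc(Nc2ccc(S(N)(=O)=O)cc2)nc1Nc1nc2ccccc2s1`: 2800 nM
compound 3, `Cc1cnc(Nc2ccc(S(C)(=O)=O)cc2)nc1Nc1nc2ccc(F)cc2s1`: > 50000 nM

Among the numbers shown, compound 1 stands lowest; the nearest is compound 2, and the change a 6.1-fold higher number from compound 1 to compound 2 (0.78 log units; beyond the scatter) follows amino in place of methyl on the sulfonyl sulfur. For compound 3 the read-out is a limit of the assay and not a number (the limit of > 50000 nM in this assay, at which 1 of the 3 values shown sits); the step of an at least 100-fold higher number from compound 1 to compound 3 (2.03 log units; beyond the scatter) follows fluoro in place of hydrogen on an aromatic carbon.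

Compound 4, `CS(=O)(=O)c1ccc(Nc2nccc(Nc3nc4ccccc4s3)n2)cc1`, is not yet measured. It differs from compound 1 by hydrogen in place of methyl on an aromatic carbon, on an aromatic carbon of a six-membered aromatic ring with 2 nitrogen, ortho to a large group, two atoms from the ring nitrogen and para to a large group. Neither measured step touches this position; both changed groups elsewhere, and both raised the number, one modestly, one at least largely. On that basis a loss of moderate size is expected, a 3.3-fold higher number from compound 1 to compound 4 (0.51 log units; beyond the scatter), and compound 4 is estimated at 1500 nM, within 300 nM to 8000 nM.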

Compound 4, half-maximal inhibitory concentration: 11300 nM
Compound 4: the middle estimate sits 7.5-fold (0.88 log units) below what was measured, and the stated range ends below it.
By their numbers in this assay, from the lowest: compound 1; then compound 2; then compound 4. At a limit, above all of these: compound 3.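

In this assay this position proves far from silent: hydrogen in place of methyl on the aromatic carbon gives a 25-fold higher number from compound 1 to compound 4 (1.39 log units; beyond the scatter), a large step from the loss of a single heavy atom. The methyl on the shared core therefore counts for much of what compound 1 shows here, even though compound 4 still returns a measured number rather than a limit. Nothing among the data shown gives a reason for this step.

From the compounds shown here alone, only methyl and hydrogen appear at this position, so it remains open whether an ethyl group, a chlorine atom, a methoxy group or an amine would hold, improve or lower the read-out. Also open, going by these compounds, is whether the same exchange would cost as much with the sulfonamide of compound 2.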